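Inverting Two Ring Stereocentres in a Peroxide Acid

The source may hold more compounds than are shown below. What is called first, only, known or untested is meant among the compounds shown, and "the series" means these compounds.

Measured compounds:
compound 1 `C=C1CCCC(C)(C)C1(O)CC/C(C)=C/CC[C@]1(C)CC[C@@H]([C@@H](C)C(=O)OC)OO1` gives > 17500 nM in a functional assay on NCI/ADR-RES cells (Homo sapiens) for inhibition; on this read-out higher numbers stand for weaker inhibition of growth and lower numbers for stronger inhibition of growth
compound 2 `CC1=C(CC/C(C)=C/CC[C@@]2(C)CC[C@@H]([C@H](C)C(=O)O)OO2)C(C)(C)CCC1` gives > 100000 nM
compound 3 `C=C1CCCC(C)(C)C1CC[C@@]1(C)CC[C@H]([C@@H](C)C(=O)O)OO1` gives 8780 nM

The value for compound 1 is a limit of the assay rather than a number. The value for compound 2 is likewise a limit. Compound 3 is the only one of the three with a measured number, and it therefore stands alone as the reference point for this series: the two other values say only where the assay stopped, not how far apart the compounds truly are.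

Compound 4 `C=C1CCCC(C)(C)C1CC[C@]1(C)CC[C@@H]([C@@H](C)C(=O)O)OO1` has the same atoms and bonds as compound 3; it differs in the two compounds have the same atoms and bonds; at least one stereo element is drawn with a configuration in one of them and without one in the other: 2 of 4 stereo elements differ; a stereocentre at a saturated ring carbon is drawn S in compound 3 and R in compound 4; a stereocentre at a saturated ring carbon is drawn R in compound 3 and S in compound 4. Within the data shown here, no pair of measured compounds shows the effect of such an inversion, so no measured step can be borrowed. A change of configuration at two ring carbons can move growth inhibition in either direction; with nothing to anchor it, a modest shift toward weaker inhibition, close to the usual scatter, is the expectation here, as an estimated step of a 1.7-fold higher number from compound 3 to compound 4 (0.23 log units; within the scatter). Compound 4 is estimated at 15000 nM, with a range from 4000 nM to 60000 nM.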

Compound 4, concentration for 50% growth inhibition: > 10000 nM
Compound 4: a limit, no number; the forecaster's own chance of this, stated with the estimate: 15%; the middle value is on the limit's open side.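

Among these compounds, compounds 3 and 4 are the first pair here that differ in one place, with the same atoms and bonds and a change only at two ring carbons, and the result for compound 4 is a limit of the assay, not a number. In this assay this gives an at least 1.1-fold higher number from compound 3 to compound 4 (0.05 log units; that floor lies within the scatter), a floor that allows either no real change or a much weaker inhibition of growth. The inversion therefore has no measured size yet, and one caution applies to the comparison: the fact that one of compounds 3 and 4 is drawn with a defined configuration and the other without, at the place where they differ

Going by these compounds, the true distance between compound 3 and compound 4 remains open, as does whether either ring carbon alone matters. On these data alone, it is also open how a primary amide in place of the carboxylic acid would behave in each configuration.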